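Three Limits and a Fourth Compound Expected Near Them

A few compounds are considered here, and "the series" means these few. Any claim that something is new, unique, unknown or untested is made for them only; others in the source may bear on it.

Compound 2 `O=C1CSC(=O)N1C[C@H]1CN(c2ccc(-n3cc(-c4ccccn4)cn3)c(F)c2)C(=O)O1` in an ADME assay on L02 cells (Homo sapiens) for cytotoxicity, read by MTT assay, with a stated time of 48 h (on this read-out higher numbers stand for weaker inhibition and lower numbers for stronger inhibition), gives > 400 ug/mL, which is a limit of the assay and not a number. Compound 1 `O=C1O[C@@H](CN2CCC(O)CC2)CN1c1ccc(-n2cc(-c3ccccn3)cn2)c(F)c1` gives > 400 ug/mL in this assay, likewise a limit. Compound 3 `O=C1O[C@@H](CNC(=O)C(F)(F)F)CN1c1ccc(-n2cc(-c3ccccn3)cn2)c(F)c1` gives > 400 ug/mL in this assay, again a limit. All three therefore stand at the limit of > 400 ug/mL in this assay, at which 3 of the 3 values shown sit, and the three measured steps, a step that the two limits leave unreadable from compound 1 to compound 2, a step that the two limits leave unreadable from compound 1 to compound 3 and a step that the two limits leave unreadable from compound 2 to compound 3, show neither a size nor a direction. Compound 4 `CONC(=O)[C@H]1CN(c2ccc(-n3cc(-c4ccccn4)cn3)c(F)c2)C(=O)O1` has not been measured; it differs from compound 2 by methoxycarbamoyl in place of (2,4-dioxo-1,3-thiazolidin-3-yl)methyl on a saturated ring carbon. Among the compounds with values here, none of the measured steps concerns this part of the shared core, and none of them has a readable size, so no step beyond the scatter can be derived from them. Given that every measured compound reaches the limit, the step expected is a step that the limit leaves unreadable from compound 2 to compound 4. Compound 4 is accordingly estimated to give about 450 ug/mL, with an expected range from 250 ug/mL to 900 ug/mL, most likely again reported only as a limit.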

Compound 4, half-maximal inhibitory concentration: > 400 ug/mL
Compound 4: only a limit was reported; the forecaster's own chance of this, stated with the estimate: 80%; the middle value lies beyond the limit too.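

Compound 4 gives > 400 ug/mL in this assay, which is a limit of the assay and not a number. Within the data shown here, no step between compound 4 and compound 1, compound 2 or compound 3 can be read, and all four stand together: the limit of > 400 ug/mL in this assay, at which 4 of the 4 values shown sit. Going by these compounds, how far these four compounds lie from one another in this assay, and in which direction, remains open.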